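Swapping the Phenyl Group on a Weak Inhibitor

A few compounds are considered here, and "the series" means these few. Any claim that something is new, unique, unknown or untested is made for them only; others in the source may bear on it.

For the measured compounds named here, in a functional assay on HCT-116 cells (Homo sapiens) for inhibition, read by MTT assay, with a stated time of 48 h (a higher number here means a weaker inhibitor, a lower number a stronger inhibitor), compound 2 `COc1cc(-c2nnc(SCC(=O)c3ccc(F)cc3)n2-c2ccc(N(C)C)cc2)cc(OC)c1OC` gives 31100 nM, the only actual number measured so far. Compound 1 `COc1cc(-c2nnc(SC)n2-c2ccc(N(C)C)cc2)cc(OC)c1OC`, the simpler relative, reports > 60000 nM, which is a limit of the assay and not a number.

Compound 3 `COc1ccc(C(=O)CSc2nnc(-c3cc(OC)c(OC)c(OC)c3)n2-c2ccc(N(C)C)cc2)cc1O` keeps everything in compound 2 except one group on the carbonyl carbon, where 3-hydroxy-4-methoxyphenyl takes the place of 4-fluorophenyl: 3-hydroxy-4-methoxyphenyl in place of 4-fluorophenyl on a carbonyl carbon.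

Going by the values given here, only one measured step can guide this comparison. That step, an at least 1.9-fold lower number from compound 1 to compound 2 (0.28 log units; that floor lies within the scatter), installed the whole (4-fluorophenyl)carbonyl group, and its floor lies within the scatter. Among the compounds with values here, it involves a different change, since no measured pair compares two groups on that carbonyl carbon. It therefore gives neither a size nor a direction to carry over, and no step beyond the scatter in this assay is firmly expected.

The estimated change is small, at a 1.6-fold lower number from compound 2 to compound 3 (0.19 log units; within the scatter). For compound 3 the expected value is 20000 nM, with an estimated range of 3000 nM to 60000 nM.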

Compound 3, half-maximal inhibitory concentration: > 100000 nM
Compound 3: a limit, no number; the forecaster's own chance of this, stated with the estimate: 15%; middle value at least 5.0-fold (0.69 log units) from the limit.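

On this carbonyl carbon, the choice of group matters: in this assay, 3-hydroxy-4-methoxyphenyl in place of 4-fluorophenyl gives an at least 3.2-fold higher number from compound 2 to compound 3 (0.50 log units; beyond the scatter). The earlier step could not show this, since its floor lay within the scatter and it installed the whole (4-fluorophenyl)carbonyl group rather than comparing two groups at this place; here a change of group alone moves the read-out beyond the scatter, towards a weaker inhibitor. Compound 3 gives a limit of the assay and not a number, so this step is only a floor and its full size remains unknown: the limit of > 100000 nM in this assay, at which 1 of the 3 values shown sits.

The step from compound 1 to compound 3 cannot be read, as both ends are limits of the assay. Also open, on these data alone, is which part of the swap carries the step, the hydroxyl, the methoxy or the loss of the fluorine, and how a plain phenyl group or a carboxylic acid would read on the same carbonyl carbon.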